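A few compounds are considered here, and "the series" means these few. Any claim that something is new, unique, unknown or untested is made for them only; others in the source may bear on it.

Series notes. Compound 1 `O=C(c1ccccc1)c1sc(N2CCN(c3ccccc3)CC2)nc1-c1ccc([N+](=O)[O-])cc1` gives 67.8% in an assay for inhibition of Polyunsaturated fatty acid 5-lipoxygenase (Homo sapiens), read by spectrophotometry, tested at 10 uM; a higher number here means more inhibition at the concentration tested (going by the name of the read-out), a lower number less inhibition. Compound 2 `COc1ccc(-c2nc(N3CCN(c4ccccc4)CC3)sc2C(=O)c2ccccc2)cc1` gives 53.1% in this assay, and compound 3 `COc1ccc(-c2nc(N(c3ccccc3)c3ccccc3)sc2C(=O)c2ccccc2)cc1` gives 92.8% in this assay, the highest of the three measured numbers. The change from compound 2 to compound 1, (nitro in place of methoxy on an aromatic carbon), moves the read-out by a number 14.7 percentage points higher from compound 2 to compound 1 (beyond the scatter). The difference between the cores of compound 3 and compound 2 is not broken down here. Compound 4 `O=C(c1ccccc1)c1sc(N(c2ccccc2)c2ccccc2)nc1-c1ccc([N+](=O)[O-])cc1` carries the same change on the core of compound 3, (nitro in place of methoxy on an aromatic carbon), with the place described in identical words, so it is the same change. The step from compound 3 to compound 4 is expected to be smaller than the earlier one, about a number 2.2 percentage points higher from compound 3 to compound 4 (within the scatter), because compound 3 starts at 92.8%, a value that already sits near the top of the read-out. Compound 4 is therefore estimated at 95%, expected between 84% and 100%.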

Compound 4, a percentage reported as inhibition, at one concentration (the size of the read-out at that concentration, not a potency): 79.6%
The estimate for compound 4 lay 15.4 percentage points above the measured number, and the stated range ends above it.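

In this assay, nitro in place of methoxy gives a number 13.2 percentage points lower from compound 3 to compound 4 (beyond the scatter), so the change does not carry over from one core to the other with the same direction. The two steps on the two cores differ: the same change on two cores in this assay, a number 14.7 percentage points higher (beyond the scatter) from compound 2 to compound 1 and a number 13.2 percentage points lower (beyond the scatter) from compound 3 to compound 4, 27.9 percentage points apart, beyond the scatter of two such steps This shows that the step measured on one of these cores does not predict the step on the other, but with one pair per core it does not show which difference between the cores is responsible, or how the change would read on a further core.

The compounds shown leave open how other groups in the same place would read on each core, for example an amine or a carboxylic acid.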